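A few compounds are considered here, and "the series" means these few. Any claim that something is new, unique, unknown or untested is made for them only; others in the source may bear on it.

Measured so far:
- compound 1 `CCCCS(=O)(=O)c1ccc(O)c(C(=O)Nc2ccc(Br)cc2)c1` gives 5.2
- compound 2 `CCCCS(=O)(=O)c1ccc(O)c(C(=O)Nc2ccc(C(F)(F)F)cc2)c1` gives 6.2
- compound 3 `CCCCCCCCS(=O)(=O)c1ccc(O)c(C(=O)Nc2ccc(C(F)(F)F)cc2)c1` gives 6.2

In a physicochemical assay for acid dissociation, compound 2 reads 6.2 and is level with compound 3, with both above compound 1. Compound 4 `CS(=O)(=O)c1ccc(O)c(C(=O)Nc2ccc(C(F)(F)F)cc2)c1` departs from compound 2 by hydrogen in place of propyl on a saturated chain carbon bound to a sulfonyl sulfur in the sulfonyl chain, turning butylsulfonyl into methylsulfonyl. The nearest evidence is the earlier change in that chain, no change at the digits printed from compound 2 to compound 3 (within the scatter) here. The other step, a number 1.00 log units higher from compound 1 to compound 2 (beyond the scatter) in size, concerns trifluoromethyl in place of bromo, which compound 4 leaves untouched. No shortening of the chain has been measured, so this rests on one step. The expected result is no change at the digits printed from compound 2 to compound 4 (within the scatter) and so nothing beyond the scatter. For compound 4 the estimate is 6.2 within a range from 5.9 to 6.5 in this assay.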

Compound 4, acid dissociation constant: 6.2
Estimate against measurement, compound 4: no gap at the digits printed, within the range that was stated.
By their numbers in this assay, from the lowest: compound 1; then compounds 2, 3 and 4 (each within the scatter of the next).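

In this assay the sulfonyl chain has now been shortened as well as lengthened: hydrogen in place of propyl gives no change at the digits printed from compound 2 to compound 4 (within the scatter) and hydrogen in place of heptyl gives no change at the digits printed from compound 3 to compound 4 (within the scatter). Across compounds 2, 3 and 4, then, the number does not follow the length of the chain on this saturated carbon bound to a sulfonyl sulfur. Nothing at hand offers a reason for this.

Still open, from the compounds shown here alone, is whether a chain ending in an amine or a carboxylic acid would read alike. Also open, going by these compounds, is whether the chain stays without consequence with bromo in place of trifluoromethyl.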